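Capping a Hydroxyl: From Compound 1 to Compound 3

The compounds below may be only part of what the source reports. "The series", "measured", "known", "first", "only" and "open" are said of these compounds alone.

Compound 1, `CC(C)NC(=O)N(CCCCCSc1nc(-c2ccccc2)c(-c2ccccc2)[nH]1)CCOCCO`: 90 nM
Compound 2, `CCOCCOCCN(CCCCCSc1nc(-c2ccc(SC)cc2)c(-c2ccc(SC)cc2)[nH]1)C(=O)NC(C)C`: 280 nM

Both were tested in an assay on microsomes from liver with sterol O-acyltransferase 1 (Rattus norvegicus) as the target; a higher number here means a weaker inhibitor, a lower number a stronger inhibitor. Compound 1 gives 90 nM, the lowest of the two numbers, while compound 2 with its 280 nM lies beyond the usual scatter above it. Compound 3, `CCOCCOCCN(CCCCCSc1nc(-c2ccccc2)c(-c2ccccc2)[nH]1)C(=O)NC(C)C`, differs from compound 1 in one place: ethyl in place of hydrogen on an oxygen on a saturated carbon. For the measured compounds named here, no measured pair differs by this change alone, so there is no step to lean on. The expected step is a 1.3-fold higher number from compound 1 to compound 3 (0.12 log units; within the scatter), within the scatter. Compound 3 is estimated at 120 nM, with a range from 50 nM to 300 nM.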

Compound 3, half-maximal inhibitory concentration: 30 nM
Compound 3: the middle estimate sits 4.0-fold (0.60 log units) above what was measured; the whole stated range lies above it.
By their numbers in this assay, from the lowest: compound 3; then compound 1; then compound 2.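

In this assay, the change from hydroxy to ethoxy gives a 3.0-fold lower number from compound 1 to compound 3 (0.48 log units; beyond the scatter), so a free hydrogen on this oxygen is not required for inhibition here. Capping it with ethyl improves the number by a modest step that lies beyond the usual scatter. No measurement available here gives a reason for this step.

Going by these compounds, it remains open whether a shorter methyl or a longer propyl on this oxygen would give a lower or higher number. Also open, on these data alone, is how an amine or a carboxylic acid in place of the hydroxy would behave.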